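Swapping Bromo for Cyclopropylmethoxy: An Expected Shift

The source may hold more compounds than are shown below. What is called first, only, known or untested is meant among the compounds shown, and "the series" means these compounds.

Measured so far:
compound 1 `O=c1cc(/C=C/c2ccc(OC(F)(F)F)cc2)oc2ccccc12` gives 28900 nM in a functional assay on PC-3 cells (Homo sapiens) for antiproliferative activity, read by MTT assay, with a stated time of 12 h; on this read-out higher numbers stand for weaker inhibition and lower numbers for stronger inhibition
compound 2 `COc1cc(OC)c2c(=O)cc(/C=C/c3ccc(Br)cc3)oc2c1` gives > 40000 nM in this assay

Compound 2 reports only a limit of this assay, > 40000 nM, and so stands at the weak end of the numbers shown (the limit of > 40000 nM in this assay, at which 1 of the 2 values shown sits). Compound 3 `COc1cc(OC)c2c(=O)cc(/C=C/c3ccc(OCC4CC4)cc3)oc2c1` awaits measurement; it differs from compound 2 by cyclopropylmethoxy in place of bromo on an aromatic carbon. Among the compounds with values here, no measured step between these compounds exists, so the expected step is a modest one downward, an at least 1.3-fold lower number from compound 2 to compound 3 (0.12 log units; that floor lies within the scatter), not clearly beyond the scatter. Compound 3 is therefore estimated at 30000 nM, expected to lie between 10000 nM and 60000 nM.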

Compound 3, half-maximal inhibitory concentration: > 40000 nM
Compound 3 was reported as a limit; the forecaster's own chance of this, stated with the estimate: 35%; at least 1.3-fold (0.12 log units) between middle value and limit.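

Within the data shown here, compound 2 and compound 3 are both reported only as limits in this assay, so no step between them can be read. As far as these compounds go, whether cyclopropylmethoxy in place of bromo shifts the activity at all stays open.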